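Methoxy to fluoro on the pendant phenyl: para versus ortho

This account rests on a few compounds, and the source may have more. Where it says the series, first, only, none or still open, it means among the compounds named here.

Compound 1 `COc1ccc(-c2cn3ccnc3c(-c3ccc4ncn(C5CCCCC5)c4c3)n2)cc1` carries a 4-methoxyphenyl on the shared core, and in a functional assay on A549 cells (Homo sapiens) for inhibition, read by sulforhodamine B assay, with a stated time of 48 h, tested at 10 uM (on this read-out lower numbers stand for less inhibition and higher numbers for more inhibition at the one concentration tested (going by the name of the read-out)), compound 1 gives 68.6%. Compound 2 `Fc1ccc(-c2cn3ccnc3c(-c3ccc4ncn(C5CCCCC5)c4c3)n2)cc1` differs from it by fluoro in place of methoxy on an aromatic carbon; in this assay compound 2 gives 12.8%, which is a number 55.8 percentage points lower from compound 1 to compound 2 (beyond the scatter). Compound 3 `COc1ccccc1-c1cn2ccnc2c(-c2ccc3ncn(C4CCCCC4)c3c2)n1` differs from compound 1 by 2-methoxyphenyl in place of 4-methoxyphenyl on an aromatic carbon; in this assay compound 3 gives 13.9%, giving a number 54.7 percentage points lower from compound 1 to compound 3 (beyond the scatter). Compound 2 and compound 3 sit within the scatter of each other, a number 1.1 percentage points higher from compound 2 to compound 3 (within the scatter).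

Compound 4 `Fc1ccccc1-c1cn2ccnc2c(-c2ccc3ncn(C4CCCCC4)c3c2)n1` is not yet measured. It differs from compound 3 by fluoro in place of methoxy on an aromatic carbon. Going by the values given here, this is the same kind of change as the one from compound 1 to compound 2, not the same one: there the group sits para to a large group, here ortho to a large group. In the measured pair that change gave a number 55.8 percentage points lower from compound 1 to compound 2 (beyond the scatter), a large step, but it started from a high number. For compound 3 to compound 4 a far smaller step is expected, because compound 3 already gives 13.9% and the read-out leaves little room to fall further. The step expected is a number 3.9 percentage points lower from compound 3 to compound 4 (within the scatter). Compound 4 is expected to give about 10% in this assay. The expected range for compound 4 runs from 0% to 30%, kept wide on the high side since nothing measured shows how the ortho placement answers to this change.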

Compound 4, a percentage reported as inhibition, at one concentration (the size of the read-out at that concentration, not a potency): 9.1%
Beside the measured number, compound 4's estimate is 0.9 percentage points above it; measured number inside the range.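

Fluoro in place of methoxy does not carry over at one size between the two placements in this assay: the same change on two cores in this assay, a number 55.8 percentage points lower (beyond the scatter) from compound 1 to compound 2 and a number 4.8 percentage points lower (within the scatter) from compound 3 to compound 4, 51 percentage points apart, beyond the scatter of two such steps. Going by these compounds alone, on the ortho-substituted side the step is small (a number 4.8 percentage points lower from compound 3 to compound 4 (within the scatter)), compound 4 stands within the scatter of its 4-fluorophenyl partner (a number 3.7 percentage points lower from compound 2 to compound 4 (within the scatter)), and the wide gap in the set remains the one to the 4-methoxyphenyl compound (a number 59.5 percentage points lower from compound 1 to compound 4 (beyond the scatter)). This shows that, among these four compounds, only compound 1 holds a high number, but it does not show why the two steps differ, and since compound 3 already stands low, the small step cannot tell how the change would behave on another compound with a high starting number.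

With compound 1 at 68.6%, the compounds shown leave open whether a different group at the place of its methoxy, such as an ethoxy, an amine or a carboxylic acid, would keep a number near that value. They also leave open how these compounds rank across a range of concentrations, since each number here comes from a single concentration and is not a potency.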